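A few compounds are considered here, and "the series" means these few. Any claim that something is new, unique, unknown or untested is made for them only; others in the source may bear on it.

The measured compounds:

Compound 1 `Cc1noc(C)c1-c1cc(OCCCCCCC(=O)NO)cc(C(=O)c2ccccc2)c1` gives 1.04 degrees C in an assay for binding affinity to histone acetyltransferase KAT2B (Homo sapiens), tested at 25 uM; a higher number here means that the compound stabilises the target more against heat, a lower number that the compound stabilises the target less.
Compound 2 `Cc1noc(C)c1-c1cc(NC(=O)CCCCC(=O)NO)cc(C(=O)c2ccccc2)c1` gives 0.31 degrees C in this assay.
Compound 3 `Cc1noc(C)c1-c1cc(NC(=O)CCCCCC(=O)NO)cc(C(=O)c2ccccc2)c1` gives 0.92 degrees C in this assay.

All three share one core, a benzophenone-like scaffold carrying an aromatic heterocycle, and differ only in the side chain that ends in the hydroxycarbamoyl group. Compound 3 stands second highest of the three numbers: compound 1 is nearest to it, and compound 2 furthest, yet both gaps lie within the usual scatter of this assay, so no real order among the three can be claimed.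

The next compound, compound 4 `Cc1noc(C)c1-c1cc(NC(=O)CCCCCCC(=O)NO)cc(C(=O)c2ccccc2)c1`, is reached from compound 3 by a single change: (hydroxycarbamoyl)methyl in place of hydroxycarbamoyl on a saturated chain carbon, five bonds along the chain from a carbonyl carbon. Among the measured compounds shown here, only one measured step bears on this kind of change, the one that leads from compound 2 to compound 3, which gave a number 0.61 degrees C higher from compound 2 to compound 3 (within the scatter). That step was within the scatter, so lengthening the chain by the same kind of unit has so far produced no clear effect in this assay. On this basis the step is expected to be small, likely slightly upward, but not beyond the scatter: a number 0.28 degrees C higher from compound 3 to compound 4 (within the scatter) is the expected step. Compound 4 is therefore estimated to give about 1.2 degrees C, with a range from 0 degrees C to 2.4 degrees C.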

Compound 4, shift of the target's melting temperature: 1.35 degrees C
Beside the measured number, compound 4's estimate is 0.15 degrees C below it, and the stated range covers the measured number.
By their numbers in this assay, from the lowest: compounds 2, 3, 1 and 4 (each within the scatter of the next).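

Adding one more carbon to the chain, the change from hydroxycarbamoyl to (hydroxycarbamoyl)methyl at this position, gives a number 0.43 degrees C higher from compound 3 to compound 4 (within the scatter), so this second lengthening also cannot be told apart from the ordinary differences between repeated measurements. The new comparison across two added carbons is the widest span in this short series, yet a number 1.0 degrees C higher from compound 2 to compound 4 (within the scatter) still gives no firm sign that chain length at this position matters in this assay: even added together, the two single steps do not clear the scatter. No measurement shown here offers an explanation for these numbers, and with so small a spread there is no clear effect to explain.

On these data alone, it remains open whether a longer chain than that of compound 4 would produce a step beyond the scatter, which is what a real effect of chain length would require. As far as these compounds go, it is equally open whether replacing the hydroxycarbamoyl end with a carboxylic acid or an amine would change the number clearly, which would show whether this end of the chain has any bearing on the read-out.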